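One double bond flipped in a cytotoxicity pair

The source may report more compounds than this note shows. Statements on the series, on what has been measured and on what is new or still open speak of the compounds shown alone.

compound 1 `Nc1ncnc2c1ncn2/C=C1/C[C@H]1[C@H](O)CO`: 93500 nM
compound 2 `Nc1ncnc2c1ncn2/C=C1\C[C@@H]1[C@@H](O)CO`: 50600 nM

In an ADME assay on Akata cells (Homo sapiens) for cytotoxicity (on this read-out lower numbers stand for higher toxicity in this test and higher numbers for lower toxicity in this test), compound 2 stands within the usual scatter of compound 1. Compound 3 `Nc1ncnc2c1ncn2/C=C1/C[C@@H]1[C@@H](O)CO` differs from compound 2 at a single place: the two compounds have the same atoms and bonds and differ only in configuration as drawn: 1 of 3 stereo elements differ; a double bond is drawn E in compound 2 and Z in compound 3. Going by the values given here, one measured step bears on this, a 1.8-fold lower number from compound 1 to compound 2 (0.27 log units; within the scatter), and it comes with the fact that compounds 1 and 2 differ only in the configuration as drawn. In that step every stereo element changed, this double bond included, and the number stayed within the scatter. Changing the double bond alone is therefore expected to give no step beyond the scatter. The expected step is a 1.3-fold higher number from compound 2 to compound 3 (0.11 log units; within the scatter). Compound 3 is estimated at 65000 nM, with an expected range of 28000 nM to 150000 nM.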

Compound 3, half-maximal cytotoxic concentration: 55000 nM
For compound 3 the middle estimate is 1.2-fold (0.07 log units) above the measured one, and the stated range covers the measured number.
By their numbers in this assay, from the lowest: compounds 2, 3 and 1 (each within the scatter of the next).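

The double bond now has a step of its own in this assay: a 1.1-fold higher number from compound 2 to compound 3 (0.04 log units; within the scatter). With the double bond held the same and both stereocentres changed, the step is a 1.7-fold lower number from compound 1 to compound 3 (0.23 log units; within the scatter). Among these three compounds, then, neither the double bond alone nor the two stereocentres together move the number beyond the scatter.

In the compounds shown, the two stereocentres always change together, so neither can be read alone. Also open, on these data alone, is whether configuration stays this silent when an amine or a carboxylic acid takes the place of a hydroxyl group.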